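Swapping 2-chlorophenyl for cyclopropyl in a small series

The source may report more compounds than this note shows. Statements on the series, on what has been measured and on what is new or still open speak of the compounds shown alone.

Compound 1 `Cc1ccc(-c2cs/c(=N\C(=O)c3ccccc3)n2C)c(C)c1`: 218 nM
Compound 2 `Cn1c(-c2ccccc2Cl)cs/c1=N\C(=O)c1ccccc1`: 268 nM

Both numbers come from a functional assay on MDA-MB-231 cells (Homo sapiens), read by microscopy and transwell migration, with a stated time of 24 h; a lower number here means a stronger inhibitor, a higher number a weaker inhibitor. There, compound 2 at 268 nM and compound 1 at 218 nM lie within the usual scatter of each other, so the two cannot be told apart, and compound 2 shares the top of this very short scale with its neighbour.

Compound 3 `Cn1c(C2CC2)cs/c1=N\C(=O)c1ccccc1` keeps the core of compound 2 and carries cyclopropyl in place of 2-chlorophenyl on an aromatic carbon. The swap sits next to the ring nitrogen and next to the ring atom that bears a methyl group.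

Going by the values given here, no measured pair yet shows what a single change does, so any expectation here is loose. A much smaller group enters than leaves, and a moderate loss of strength in this assay seems more likely than a gain, though a change within the scatter remains possible. The expected move is a 3.0-fold higher number from compound 2 to compound 3 (0.47 log units; beyond the scatter), towards a weaker inhibitor. For compound 3 the estimate is 800 nM, with an expected range of 200 nM to 3500 nM.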

Compound 3, half-maximal inhibitory concentration: 104 nM
The estimate for compound 3 lay 7.7-fold (0.89 log units) above the measured number; measured number outside the range, below it.
By their numbers in this assay, from the lowest: compound 3; then compounds 1 and 2 (each within the scatter of the next).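

Placing cyclopropyl on this aromatic carbon instead of 2-chlorophenyl gives a 2.6-fold lower number from compound 2 to compound 3 (0.41 log units; beyond the scatter) in this assay, the first single change in this small series whose effect can be read. For this pair, neither the six-membered aromatic ring nor its chlorine is required for a low number at this position, and the much smaller, non-aromatic ring does better in this assay. Why the number falls cannot be told, as nothing measured here bears on the cause.

Going by these compounds alone, this single pair gives only one point of comparison at this position, so it remains open whether a smaller group such as methyl, a larger saturated ring such as cyclohexyl, or an amine would lower the number further or raise it again. As far as these compounds go, it is also open whether cyclopropyl would bring a similar step if the methyl group on the neighbouring ring atom were replaced by a longer chain such as propyl.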